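Ester to primary amide on the thiazole series

The compounds below may be only part of what the source reports. "The series", "measured", "known", "first", "only" and "open" are said of these compounds alone.

Measured compounds:
compound 1 `CCOC(=O)c1sc(-c2cccc(NC(=O)c3ccccc3)c2)nc1Nc1ccc(N2CCN(C)CC2)cc1` – in a functional assay on Raji cells (Homo sapiens) for antiproliferative activity, read by CCK-8 assay, with a stated time of 72 h (on this read-out lower numbers stand for stronger inhibition and higher numbers for weaker inhibition), compound 1 is recorded as "not determined" (no result reported)
compound 2 `CCOC(=O)c1sc(-c2cccc(NC(=O)c3ccccc3F)c2)nc1Nc1ccc(N2CCN(C)CC2)cc1` – 9270 nM
compound 3 `CCOC(=O)c1sc(-c2cccc(NC(=O)c3ccc(F)c(Cl)c3)c2)nc1Nc1ccc(N2CCN(C)CC2)cc1` – in this assay compound 3 is recorded as "not determined" (no result reported)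

Of the three measured compounds, only compound 2 carries a number: in this assay compound 2 gives 9270 nM. Compound 1 and compound 3 are recorded without a result, so there is nothing to place compound 2 against within the series; it stands alone on the numbers shown, and no step between measured compounds can be read off.

Compound 4 `CN1CCN(c2ccc(Nc3nc(-c4cccc(NC(=O)c5ccccc5F)c4)sc3C(N)=O)cc2)CC1` is the next entry to be measured. It differs from compound 2 in one place: amino in place of ethoxy on a carbonyl carbon.

Going by the values given here, with no measured pair available that reports on a change at this carbonyl carbon, the size and direction of the step cannot be inferred from the data; the working assumption is a step not clearly beyond the usual scatter, with the direction open. The step expected from compound 2 to compound 4 is a 1.5-fold lower number from compound 2 to compound 4 (0.19 log units; within the scatter). For compound 4 the estimate in this assay is 6000 nM, with a range from 1500 nM to 25000 nM.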

Compound 4, half-maximal inhibitory concentration: 3270 nM
For compound 4 the middle estimate is 1.8-fold (0.26 log units) above the measured one; measured number inside the range.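

In this assay, going by these compounds alone, the change from ethoxycarbonyl to carbamoyl gives a 2.8-fold lower number from compound 2 to compound 4 (0.45 log units; beyond the scatter), the first measured step. This shows that the group on this carbonyl carbon affects the read-out: the step is modest but beyond the usual scatter, and the ethoxy group is not needed for activity, with amino in its place giving stronger inhibition. The data offer no measured basis for explaining the step, which therefore stands as an observation from a single pair.

Steps involving compound 1 and compound 3 cannot be read, so it remains unknown whether the same change would carry the same size and direction on their benzamide groups. Also open, going by these compounds, is how far this position can be taken, for example whether a carboxylic acid, a methylamino or dimethylamino group, or an ester with a longer chain on the same carbonyl carbon would extend, match or reverse the step.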